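Swapping nitro for cyano on a shared core

The source may report more compounds than this note shows. Statements on the series, on what has been measured and on what is new or still open speak of the compounds shown alone.

Of the compounds shown here, two with the same core have been tested in a functional assay on LOX IMVI cells (Homo sapiens) for inhibition, read by sulforhodamine B assay, with a stated time of 48 h, tested at 10 uM; on this read-out higher numbers stand for more inhibition of growth at the one concentration tested and lower numbers for less inhibition of growth. Compound 2 `CCOC(=O)c1ccc(Nc2ccnc(SCC(=O)c3ccc([N+](=O)[O-])cc3)n2)cc1` gives 10%. Compound 1 `CC(=O)c1ccc(Nc2ccnc(SCC(=O)c3ccc(Br)cc3)n2)cc1` gives 14% in this assay, a gap from compound 2 that lies within the usual scatter. Among the compounds with values here, these two differ in more than one place, so no single step joins them. Compound 3 `CCOC(=O)c1ccc(Nc2ccnc(SCC(=O)c3ccc(C#N)cc3)n2)cc1` is not yet measured. It differs from compound 2 by cyano in place of nitro on an aromatic carbon. Within the data shown here, no measured pair shows this exchange, so the step is expected to be a number 2 percentage points higher from compound 2 to compound 3 (within the scatter), nothing beyond the scatter. Compound 3 is estimated at 12%, between 0% and 28%.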

Compound 3, percent growth inhibition at one concentration: 20%
The estimate for compound 3 lay 8 percentage points below the measured number; the measured number falls inside the stated range.
By their numbers in this assay, from the lowest: compounds 2, 1 and 3 (each within the scatter of the next).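

Within the data shown here, on the aromatic carbon para to a large group, replacing nitro with cyano in this assay gives a first direct reading for this position, a step of a number 10 percentage points higher from compound 2 to compound 3 (within the scatter) on the shared core. This single exchange, 4-nitrophenyl to 4-cyanophenyl, therefore shows no shift that stands clear of the usual variation between repeats. Nothing available explains the size of this step. Still open, as far as these compounds go, is whether an amine or a carboxylic acid at this position would move growth inhibition beyond that variation.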